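Moving the fluorine on the alkyne-linked phenyl ring

The source may hold more compounds than are shown below. What is called first, only, known or untested is meant among the compounds shown, and "the series" means these compounds.

Compound 2 `CNC(=O)[C@@]12C[C@@H]1[C@@H](n1cnc3c(NC)nc(C#Cc4cccc(F)c4)nc31)[C@H](O)[C@@H]2O` has been measured in an assay on CHO cells for displacement of a labelled ligand from adenosine receptor A1 (Homo sapiens), read by scintillation counting, with a stated time of 60 min, tested at 10 uM; on this read-out lower numbers stand for less inhibition and higher numbers for more inhibition at the one concentration tested (going by the name of the read-out). Among the measured compounds shown here, compound 2 gives 14%, and the only other measured compound, compound 1 `CNC(=O)[C@@]12C[C@@H]1[C@@H](n1cnc3c(NC)nc(C#Cc4ccccc4)nc31)[C@H](O)[C@@H]2O`, gives 18%; the step of a number 4 percentage points lower from compound 1 to compound 2 (within the scatter) lies within the scatter, so compound 2 sits alongside compound 1 rather than apart from it. Compound 3 `CNC(=O)[C@@]12C[C@@H]1[C@@H](n1cnc3c(NC)nc(C#Cc4ccc(F)cc4)nc31)[C@H](O)[C@@H]2O` is not yet measured and differs from compound 2 by 4-fluorophenyl in place of 3-fluorophenyl on a triple-bonded carbon. For the measured compounds named here, no measured step moves a fluorine between ring positions, and the single measured step, adding fluorine in place of hydrogen, stayed within the scatter. The expected step is a number 1 percentage points higher from compound 2 to compound 3 (within the scatter), nothing beyond the scatter. Compound 3 is therefore estimated at 15%, between 5% and 28%.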

Compound 3, a percentage reported as inhibition, at one concentration (the size of the read-out at that concentration, not a potency): 27%
Compound 3: middle estimate off by 12 percentage points, on the low side; the range from low to high includes it.
By their numbers in this assay, from the lowest: compounds 2, 1 and 3 (each within the scatter of the next, the first and the last beyond it).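

Moving the fluorine from 3-fluorophenyl to 4-fluorophenyl gives a number 13 percentage points higher from compound 2 to compound 3 (beyond the scatter) in this assay, the first step in this series beyond the scatter, so where the fluorine sits on this ring can matter. Yet replacing hydrogen with fluorine to give 4-fluorophenyl gives a number 9 percentage points higher from compound 1 to compound 3 (within the scatter), so compound 3 does not stand apart from compound 1. Nothing at hand explains the difference between the two fluorine placements.

Still open, as far as these compounds go, is whether a chlorine, a methoxy group or an amine in place of the fluorine of 4-fluorophenyl would shift the number further.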